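A few compounds are considered here, and "the series" means these few. Any claim that something is new, unique, unknown or untested is made for them only; others in the source may bear on it.

For the measured compounds named here, the three measured members share one core and were all tested in a functional assay on MIA PaCa-2 cells (Homo sapiens) for inhibition, read by MTT assay, with a stated time of 7 days; on this read-out lower numbers stand for stronger inhibition and higher numbers for weaker inhibition. Compound 1 `CCN(CC)S(=O)(=O)c1ccc(S(=O)(=O)N2CCC[C@@H](C(=O)NC3COC3)C2)cc1` gives 2300 nM in this assay, the lower of the two numbers reported, and the gap to the next compound lies beyond the usual scatter. Compound 2 `CCOC(=O)[C@H]1CCN(S(=O)(=O)c2ccc(S(=O)(=O)N(CC)CC)cc2)C1` gives 29200 nM in this assay. For compound 3 `CCOC(=O)N1CCC[C@H](S(=O)(=O)c2ccc(S(=O)(=O)N(CC)CC)cc2)C1` this assay reports only a limit, > 30000 nM, which is the limit of > 30000 nM in this assay, at which 1 of the 3 values shown sits, and not a number.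

Compound 4 `CCN(CC)S(=O)(=O)c1ccc(S(=O)(=O)N2CCC[C@@H](C(=O)NC3CN(S(C)(=O)=O)C3)C2)cc1` has not yet been measured. It differs from compound 1 in a single place: 1-(methylsulfonyl)azetidin-3-yl in place of oxetan-3-yl on an amide-type nitrogen. Going by the values given here, no pair of measured compounds differs only at this position, so the step has to be judged from the change alone. A small step is expected in this assay, within the usual scatter and in no clear direction. The step expected here is a 1.1-fold higher number from compound 1 to compound 4 (0.04 log units; within the scatter). Compound 4 is estimated at 2500 nM in this assay, with a range from 900 nM to 7000 nM.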

Compound 4, half-maximal inhibitory concentration: 2500 nM
The estimate for compound 4 equals the measured number at the digits printed; measured number inside the range.
By their numbers in this assay, from the lowest: compounds 1 and 4 (each within the scatter of the next); then compound 2. At a limit, above all of these: compound 3.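

In this assay, the step from oxetan-3-yl to 1-(methylsulfonyl)azetidin-3-yl on the amide-type nitrogen is a 1.1-fold higher number from compound 1 to compound 4 (0.04 log units; within the scatter), so the two numbers cannot be told apart. For the compounds shown here, this is the first direct look at this position, since no earlier pair of compounds differed only here, and it shows that a group with more heavy atoms and an added methylsulfonyl can stand on this nitrogen without a step beyond the scatter. No measurement shown explains why compound 1 and compound 4 read alike.

Going by these compounds alone, with only this one change at the position, it remains open whether a simple amine, a carboxylic acid or a longer alkyl chain on this nitrogen would give a similar number. Compounds 2 and 3 differ from compound 1 in more than one place, so they add nothing about this position.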